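The source may report more compounds than this note shows. Statements on the series, on what has been measured and on what is new or still open speak of the compounds shown alone.

In a functional assay on IMR-32 cells (Homo sapiens) for cytotoxicity, read by sulforhodamine B assay, with a stated time of 48 h (a higher number here means a weaker inhibitor, a lower number a stronger inhibitor), compound 1 (`C=CCOc1c(Cl)cccc1C(=O)c1cccnc1`) gives 94000 nM and compound 2 (`C=CCOc1ccc(C)cc1C(=O)c1cccnc1`) gives 87000 nM so the two sit within the usual scatter of each other. Among the measured compounds shown here, no step between compounds differing in one place has been measured yet. Compound 3 (`C=CCOc1ccccc1C(=O)c1cccnc1`) is the next entry for this assay and departs from compound 2 as follows: hydrogen in place of methyl on an aromatic carbon (in words, hydrogen in place of methyl on an aromatic carbon). For the measured compounds named here, with no measured step to go on, no shift beyond the scatter is expected in either direction, and the working reference is compound 2 at 87000 nM as the closest structure. The estimated step is a 1.1-fold higher number from compound 2 to compound 3 (0.04 log units; within the scatter) (expected to stay within the scatter). For compound 3 the estimated value is 95000 nM with 50000 nM to 160000 nM as the expected range.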

Compound 3, half-maximal inhibitory concentration: 44000 nM
Compound 3: middle estimate off by 2.2-fold (0.33 log units), on the high side; the whole stated range lies above it.
By their numbers in this assay, from the lowest: compounds 3, 2 and 1 (each within the scatter of the next, the first and the last beyond it).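

In this assay, among the compounds shown here, the replacement of chloro by hydrogen on an aromatic carbon gives the first single-place step beyond the scatter, though a modest one: a 2.1-fold lower number from compound 1 to compound 3 (0.33 log units; beyond the scatter) in this series. Hydrogen in place of methyl, on the aromatic carbon para to an allyloxy group, gives a 2.0-fold lower number from compound 2 to compound 3 (0.30 log units; within the scatter) and stays within the scatter, so no effect of that methyl is established at this position. No measurement at hand accounts for either step.

Going by these compounds, whether an amine or a carboxylic acid para to an allyloxy group would shift the number beyond the scatter remains open. Also open, on these data alone, is how a longer chain in place of the allyloxy group would read in this assay on the core of compound 3.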